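A few compounds are considered here, and "the series" means these few. Any claim that something is new, unique, unknown or untested is made for them only; others in the source may bear on it.

Measured compounds in an assay on HEK293 cells for positive allosteric modulation of metabotropic glutamate receptor 5 (Homo sapiens), read by FLIPR, with a stated time of 1 h; a lower number here means that less compound is needed, a higher number that more compound is needed for the effect:
- compound 1 `CCCCN1CCc2nc(C#Cc3ccccc3)sc2C1`: 110 nM
- compound 2 `O=C(CC1CCOCC1)N1CCc2nc(C#Cc3ccccc3)sc2C1`: 470 nM

Within the data shown here, compound 2 gives the higher of the two numbers so far in this assay; compound 1, the only comparator, sits at a lower value, and the gap between them lies beyond the usual scatter. Both share the same core carrying the phenylethynyl-substituted thiazole; compound 1 bears a butyl chain on the ring nitrogen, compound 2 an acyl group. Among the measured compounds shown here, no step between these two is available as a like-for-like pair, so only the two values themselves are on hand.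

Compound 3 `Cc1nc(C(=O)N2CCc3nc(C#Cc4ccccc4)sc3C2)cs1` keeps the amide of compound 2 and changes the group on the carbonyl carbon: 2-methyl-1,3-thiazol-4-yl in place of (oxan-4-yl)methyl on a carbonyl carbon. For the measured compounds named here, there is no measured precedent for an aryl in place of a saturated ring-bearing chain on this carbonyl, so the direction cannot be read from the data. A step of modest size is expected, a 1.6-fold lower number from compound 2 to compound 3 (0.19 log units; within the scatter), with a lower number somewhat more likely than a higher one but within a broad band. For compound 3 the estimate in this assay is 300 nM, ranging from 80 nM to 1200 nM.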

Compound 3, half-maximal effective concentration: 220 nM
Beside the measured number, compound 3's estimate is 1.4-fold (0.13 log units) above it; the range from low to high includes it.
By their numbers in this assay, from the lowest: compounds 1 and 3 (each within the scatter of the next); then compound 2.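

In this assay the group on the carbonyl carbon now shows a measured influence on the read-out: 2-methyl-1,3-thiazol-4-yl in place of (oxan-4-yl)methyl gives a 2.1-fold lower number from compound 2 to compound 3 (0.33 log units; beyond the scatter) and so only just clears the usual scatter. The higher number of compound 2 therefore does not hold for every acyl group on the ring nitrogen, since a 2.0-fold higher number from compound 1 to compound 3 (0.30 log units; within the scatter) leaves the amide compound 3 and the butyl amine compound 1 within the scatter of each other. Among these compounds, nothing on hand accounts for either step, and with only two acyl groups no trend can be drawn for this position.

Still open, on these data alone, is which part of the change carries the step: the aromatic ring, its methyl group or the loss of the methylene link to the carbonyl carbon, which a phenyl or an unsubstituted 1,3-thiazol-4-yl on that carbon could help to separate. Among the compounds shown here, also open is how a longer chain than butyl on the ring nitrogen would compare, as this position has only one alkyl group to go on.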